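The source may report more compounds than this note shows. Statements on the series, on what has been measured and on what is new or still open speak of the compounds shown alone.

Measured so far in an ADME assay (liver) for metabolic stability, with Liver microsome (Rattus norvegicus) as the target, using microsomes and NADPH, with a stated time of 30 min, tested at 1 uM; a higher number here means faster removal of the compound, a lower number slower removal:
- compound 1 `Nc1ccc(S(=O)(=O)N2CCN(c3ncc(C(O)(C(F)(F)F)C(F)(F)F)cc3C#CC3CC3)CC2)cn1`: 67 mL.min-1.g-1
- compound 2 `Nc1ccc(S(=O)(=O)N2CCN(c3ncc(C(O)(C(F)(F)F)C(F)(F)F)cc3C#CCCO)CC2)cn1`: 68 mL.min-1.g-1
- compound 3 `CCn1cc(-c2cc(C(O)(C(F)(F)F)C(F)(F)F)cnc2N2CCN(S(=O)(=O)c3ccc(N)nc3)CC2)cn1`: 194 mL.min-1.g-1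

Compound 3 has the highest number of the three, so it is removed fastest. The next change gives compound 4 `Nc1ccc(S(=O)(=O)N2CCN(c3ncc(C(O)(C(F)(F)F)C(F)(F)F)cc3-c3ccccc3O)CC2)cn1`, with 2-hydroxyphenyl in place of 1-ethyl-1H-pyrazol-4-yl on an aromatic carbon.

Going by the values given here, no measured compound carries 2-hydroxyphenyl, so the evidence is indirect. Putting 1-ethyl-1H-pyrazol-4-yl in place of 2-cyclopropylethynyl gave a 2.9-fold higher number from compound 1 to compound 3 (0.46 log units; beyond the scatter), and putting it in place of 4-hydroxybut-1-yn-1-yl gave a 2.9-fold higher number from compound 2 to compound 3 (0.46 log units; beyond the scatter). Both steps are modest and replace a triple-bonded group with an aromatic ring. The change at the end of the triple bond, a 1.0-fold higher number from compound 1 to compound 2 (0.01 log units; within the scatter), stayed within the scatter.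

Compound 4 keeps an aromatic ring on that carbon, as does compound 3 at 194 mL.min-1.g-1, so only a small shift is expected in this assay, none beyond the scatter. The expected change is a 1.5-fold lower number from compound 3 to compound 4 (0.17 log units; within the scatter). For compound 4 the estimated value is 130 mL.min-1.g-1, with an expected range from 55 mL.min-1.g-1 to 300 mL.min-1.g-1.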

Compound 4, intrinsic clearance in microsomes: 125 mL.min-1.g-1
Estimate against measurement, compound 4: 1.0-fold (0.02 log units) above, and the stated range covers the measured number.
By their numbers in this assay, from the lowest: compounds 1, 2, 4 and 3 (each within the scatter of the next, the first and the last beyond it).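

In this assay, 2-hydroxyphenyl on this aromatic carbon cannot be told apart from 1-ethyl-1H-pyrazol-4-yl (a 1.6-fold lower number from compound 3 to compound 4 (0.19 log units; within the scatter)), although the ring changes from a five-membered one with two nitrogens to a six-membered all-carbon one bearing a hydroxyl. It also cannot be told apart from either triple-bonded group (a 1.8-fold higher number from compound 2 to compound 4 (0.26 log units; within the scatter)) (a 1.9-fold higher number from compound 1 to compound 4 (0.27 log units; within the scatter)), so an aromatic ring here does not always place a compound beyond the scatter of those two: compound 3 lies beyond it, compound 4 does not. Nothing measured here explains this result.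

On these data alone, how a plain phenyl or a 2-aminophenyl group would compare on this carbon remains open, and that comparison would isolate what the hydroxyl itself contributes. Also open, as far as these compounds go, is how a saturated ring amine such as morpholine would behave at this position.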